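Diethylamino for Piperidin-1-yl at the Amide Carbonyl

A few compounds are considered here, and "the series" means these few. Any claim that something is new, unique, unknown or untested is made for them only; others in the source may bear on it.

Compound 1 `O=C1C=CC(=O)C(c2cc(-c3ccc(C(=O)N4CCC(C(F)(F)F)CC4)s3)on2)=C1` gives only a limit of the assay: > 30000 nM.
Compound 2 `O=C1C=CC(=O)C(c2cc(-c3ccc(C(=O)N4CCCCC4)s3)on2)=C1` gives only a limit of the assay: > 30000 nM.
Compound 3 `COc1ccc(OC)c(-c2cc(-c3ccc(C(=O)N(C)Cc4ccccc4)s3)on2)c1` gives only a limit of the assay: > 30000 nM.

All three were tested in a functional assay on PC-3 cells (Homo sapiens) for cytotoxicity, read by XTT assay, with a stated time of 72 h; a lower number here means a stronger inhibitor, a higher number a weaker inhibitor. Among the compounds with values here, the one change measured within the set, hydrogen in place of trifluoromethyl on a saturated ring carbon, runs a step that the two limits leave unreadable from compound 1 to compound 2, so its size cannot be read. Compound 2 therefore stands at the limit rather than at a number, and it shares that position with every other value shown, because of the limit of > 30000 nM in this assay, at which 3 of the 3 values shown sit.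

Compound 4 `CCN(CC)C(=O)c1ccc(-c2cc(C3=CC(=O)C=CC3=O)no2)s1` differs from compound 2 by one change at the amide: diethylamino in place of piperidin-1-yl on a carbonyl carbon. Within the data shown here, no measured step bears directly on this change, and the single step measured is unreadable, so nothing here points to a gain or loss beyond the scatter. The expectation is that compound 4 also stays at the limit, a step that the limit leaves unreadable from compound 2 to compound 4. Compound 4 is thus estimated at 50000 nM, in a range from 20000 nM to 200000 nM.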

Compound 4, half-maximal inhibitory concentration: 8900 nM
Compound 4: middle estimate off by 5.6-fold (0.75 log units), on the high side; measured number outside the range, below it.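

In this assay, within the data shown here, the group on the amide carbonyl proves able to move the result, and compound 4 gives the first true number in the set. Putting diethylamino, which has no ring, in place of piperidin-1-yl runs an at least 3.3-fold lower number from compound 2 to compound 4 (0.52 log units; beyond the scatter), and putting it in place of 4-(trifluoromethyl)piperidin-1-yl runs an at least 3.3-fold lower number from compound 1 to compound 4 (0.52 log units; beyond the scatter). Both steps give only a minimum size, because each starts from a compound that stands at a limit: the limit of > 30000 nM in this assay, at which 3 of the 4 values shown sit.

Going by these compounds, it remains open whether the lower number follows from opening the ring or from the ethyl groups themselves, a question that dimethylamino or pyrrolidin-1-yl on the same carbonyl carbon could help to settle. On these data alone, how the number would respond to a longer chain, such as dipropylamino, or to morpholin-4-yl also remains unknown.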